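The source may report more compounds than this note shows. Statements on the series, on what has been measured and on what is new or still open speak of the compounds shown alone.

Measured so far in a functional assay on HL-60 cells (Homo sapiens) for inhibition, with a stated time of 72 h; a lower number here means a stronger inhibitor, a higher number a weaker inhibitor:
compound 1 `OC[C@H]1O[C@@H](n2cnc3c(CSCc4ccccc4)ncnc32)[C@H](O)[C@@H]1O` gives 10700 nM
compound 2 `COCc1ncnc2c1ncn2[C@@H]1O[C@H](CO)[C@@H](O)[C@H]1O` gives 13000 nM

Compound 2 stands with the highest of the two numbers in this assay, and its nearest neighbour is compound 1, the gap being a 1.2-fold higher number from compound 1 to compound 2 (0.08 log units; within the scatter). The next compound, compound 3 `CC(C)N(Cc1ncnc2c1ncn2[C@@H]1O[C@H](CO)[C@@H](O)[C@H]1O)C(C)C`, changes the same place on the shared core once more: diisopropylamino in place of methoxy on a saturated chain carbon bound to an aromatic carbon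

Among the measured compounds shown here, one measured step bears on this. The exchange at the saturated chain carbon bound to an aromatic carbon, from benzylsulfanyl to methoxy, gave a 1.2-fold higher number from compound 1 to compound 2 (0.08 log units; within the scatter), so two quite different groups at this place left the number in this assay where it was. For the measured compounds named here, with only that one step to go on, nothing points to a large move for diisopropylamino in place of methoxy; the expected step is a 1.1-fold lower number from compound 2 to compound 3 (0.03 log units; within the scatter), within the scatter. Compound 3 is therefore estimated at 12000 nM, with a range of 4000 nM to 36000 nM.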

Compound 3, half-maximal inhibitory concentration: 13000 nM
Compound 3: middle estimate off by 1.1-fold (0.03 log units), on the low side, and the stated range covers the measured number.
By their numbers in this assay, from the lowest: compounds 1, 2 and 3 (each within the scatter of the next).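

In this assay, diisopropylamino in place of methoxy gives no change at the digits printed from compound 2 to compound 3 (within the scatter), and diisopropylamino in place of benzylsulfanyl gives a 1.2-fold higher number from compound 1 to compound 3 (0.08 log units; within the scatter), both on a saturated chain carbon bound to an aromatic carbon. The flat reading therefore now extends to a group with more heavy atoms than methoxy, and it spans groups joined through oxygen, sulfur and nitrogen. Nothing on hand accounts for this flat reading.

As far as these compounds go, it remains open whether a carboxylic acid, a primary amine or a bare methyl at this place would move the number beyond the scatter. Also open, from the compounds shown here alone, is whether the level shared by these three compounds depends on this place at all, or on the rest of the shared core.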